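The compounds below may be only part of what the source reports. "The series", "measured", "known", "first", "only" and "open" are said of these compounds alone.

Measured so far in an ADME assay on HEK293 cells (Homo sapiens) for inhibition, read by CellTiter-Glo, with a stated time of 96 h, tested at 100 uM; on this read-out higher numbers stand for more inhibition at the one concentration tested (going by the name of the read-out) and lower numbers for less inhibition:
- compound 2, `CC(C)(C)OC(=O)/C=C\NC(=O)[C@H](O)C(C)(C)CO`, gives -9%
- compound 3, `CCOC(=O)/C=C\NC(=O)[C@H](O)C(C)(C)CO`, gives -6%
- compound 1, `COC(=O)/C=C\NC(=O)[C@H](O)C(C)(C)CO`, gives "not determined" (no result reported)

Compound 2 stands at the lowest of the two numbers recorded in this assay. Its nearest neighbour is compound 3, and the step of a number 3 percentage points higher from compound 2 to compound 3 (within the scatter) is within the scatter, so the two compounds cannot be placed in any order on this read-out. Both sit close to zero, meaning essentially no inhibition at the single concentration tested.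

The move to compound 4, `CC(C)(C)OC(=O)/C=C/NC(=O)[C@H](O)C(C)(C)CO`, is the two compounds have the same atoms and bonds and differ only in configuration as drawn: 1 of 2 stereo elements differ; a double bond is drawn Z in compound 2 and E in compound 4.

Going by the values given here, none of the measured steps bears directly on this change. Among the compounds with values here, the only step recorded, from compound 2 to compound 3, concerns the ester group and not the geometry of the double bond, and even that step stayed within the scatter. With both measured compounds sitting near zero and no shown step pointing away from that, the expectation for compound 4 is a step of a number 4 percentage points higher from compound 2 to compound 4 (within the scatter) that does not rise beyond the scatter in this assay. Compound 4 is therefore estimated at -5%, with a likely range from -15% to 10%.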

Compound 4, a percentage reported as inhibition, at one concentration (the size of the read-out at that concentration, not a potency): -1%
Compound 4: middle estimate off by 4 percentage points, on the low side; the range from low to high includes it.
By their numbers in this assay, from the lowest: compounds 2, 3 and 4 (each within the scatter of the next).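

Going by these compounds alone, until now only the ester group had varied, always with the double bond drawn Z, so compound 4 gives the first reading on the double bond itself in this assay: E in place of Z on the tert-butyl ester gives a number 8 percentage points higher from compound 2 to compound 4 (within the scatter). With the tert-butyl ester in place, the geometry of this double bond therefore does not carry the read-out beyond the scatter, and the series stays close to zero at the single concentration tested. This reading concerns configuration alone, with no other structural feature involved, because the comparison rests on a single difference: the fact that compounds 2 and 4 differ only in the configuration as drawn

The E double bond is shown here only with the tert-butyl ester, which leaves open whether the same holds with the ethyl ester of compound 3 or with other ester groups. Also open, on these data alone, is how this assay reads when a carboxylic acid stands in place of the ester, or when a longer chain sits on the ester oxygen, in either double bond geometry.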